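A few compounds are considered here, and "the series" means these few. Any claim that something is new, unique, unknown or untested is made for them only; others in the source may bear on it.

Compound 1 `CC(=O)Nc1cc(-c2ccc(OC[C@@](C)(N)CC(C)C)c(F)c2)ccn1`: 0.24 nM
Compound 2 `CC(=O)Nc1cc(-c2cc(F)c(OC[C@@H](N)CC(C)C)c(F)c2)ccn1`: 27 nM
Compound 3 `CC(=O)Nc1cc(-c2ccc(OC[C@@H](N)CC(C)C)c(F)c2)ccn1`: 0.52 nM

All three compounds share the same core and were tested in an assay on brain (strain C57BL6) for displacement of a labelled ligand from AP2-associated protein kinase 1 (Mus musculus), read by scintillation counting, with a stated time of 1 h; a higher number here means a weaker inhibitor, a lower number a stronger inhibitor. Compound 3 stands second among the three numbers: compound 1 sits closest to it, with a 2.2-fold higher number from compound 1 to compound 3 (0.34 log units; beyond the scatter), while compound 2 lies far away, with a 52-fold lower number from compound 2 to compound 3 (1.72 log units; beyond the scatter).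

Compound 4 `CC(=O)Nc1cc(-c2ccc(OC[C@@H](N)CC(C)C)c(C)c2)ccn1` has not been measured yet. It differs from compound 3 in one place: methyl in place of fluoro on an aromatic carbon. Within the data shown here, of the two measured steps, the one from compound 1 to compound 3 concerns the chain bound to the oxygen, not the ring, and so says little about this change. The step from compound 2 to compound 3 is the relevant one: it shows that exchanging a single atom on this ring can move the number a great deal. Among the measured compounds shown here, that step, however, swapped fluoro for hydrogen, whereas here a methyl enters, and nothing measured so far shows what a methyl at this spot does. A change beyond the scatter is therefore plausible in either direction, and the expectation must stay wide.

Compound 4 is estimated at 1 nM, within a range of 0.2 nM to 5 nM, which means an expected 1.9-fold higher number from compound 3 to compound 4 (0.28 log units; within the scatter).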

Compound 4, inhibition constant: 0.08 nM
Compound 4: the middle estimate sits 13-fold (1.10 log units) above what was measured, outside the stated range (below it).
By their numbers in this assay, from the lowest: compound 4; then compound 1; then compound 3; then compound 2.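

In this assay, the aromatic carbon ortho to the (2-amino-4-methylpentyl)oxy group does not need fluoro for a low number, since methyl in its place gives a 6.5-fold lower number from compound 3 to compound 4 (0.81 log units; beyond the scatter) at this carbon. Among these compounds, the earlier ring step, a 52-fold lower number from compound 2 to compound 3 (1.72 log units; beyond the scatter) on a different aromatic carbon, left this one untested, so this is the first evidence that a change here also moves the number beyond the scatter, even though one heavy atom replaces one heavy atom and the counts of hydrogen-bond donors, acceptors and net charge stay the same. Nothing shown here explains why methyl gives the lower number.

On these data alone, whether this result is particular to methyl remains open, and hydrogen, chloro, methoxy or a longer chain such as ethyl at this carbon would help to show how much the group matters. Also open is whether methyl at this carbon would have the same effect alongside the 1-amino-1,3-dimethylbutyl group of compound 1 , since the two changes appear together in none of the compounds shown.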